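The source may report more compounds than this note shows. Statements on the series, on what has been measured and on what is new or still open speak of the compounds shown alone.

Measured so far in an assay for inhibition of HSP60/HSP10 (Homo sapiens), with a stated time of 60 min; on this read-out higher numbers stand for weaker inhibition and lower numbers for stronger inhibition:
Compound 1 `COc1c(Br)cc(Br)cc1C(=O)Nc1ccccc1` gives > 100000 nM, which is a limit of the assay and not a number.
Compound 2 `O=C(Nc1cccc(Cl)c1)c1cc(Br)cc(Br)c1` gives > 100000 nM, again a limit of the assay.
Compound 3 `O=C(Nc1ccc(Sc2nc3ccccc3s2)c(Cl)c1)c1cccc(Br)c1O` gives 6900 nM.

Among the measured compounds shown here, compounds 1 and 2 sit at the limit of > 100000 nM in this assay, at which 2 of the 3 values shown sit, so compound 3 is the only compound with a real number in this assay, and it is the sole point of reference for anything new. Compound 3 carries a bromo group and a hydroxy group on the ring attached to the amide carbonyl, and a long sulfur-linked substituent on the aniline side.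

Compound 4 `O=C(Nc1ccc(Sc2nc3ccccc3s2)c(Cl)c1)c1cccc(Br)c1` keeps everything except one thing: hydrogen in place of hydroxy on an aromatic carbon. Put simply, the phenol is gone and a plain aromatic hydrogen takes its place on the 3-bromophenyl ring.

For the measured compounds named here, no measured pair shows this exact change, so its effect has to be guessed from compound 3 alone. Taking away a hydrogen-bond donor and acceptor in one move is the kind of edit that, in many series, costs some potency rather than gaining it, and the loss here is expected to be modest but a little beyond the usual scatter, as an estimated step of a 2.9-fold higher number from compound 3 to compound 4 (0.46 log units; beyond the scatter) in this assay.

Compound 4 is therefore estimated to give about 20000 nM, most likely between 5000 nM and 100000 nM.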

Compound 4, half-maximal inhibitory concentration: > 100000 nM
Compound 4: a limit, no number (the forecaster's own chance of this, stated with the estimate: 30%); middle value at least 5.0-fold (0.69 log units) from the limit.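

In this assay, the hydroxy group of compound 3 proves to matter a great deal: replacing it with hydrogen, which turns 3-bromo-2-hydroxyphenyl into 3-bromophenyl, gives an at least 14-fold higher number from compound 3 to compound 4 (1.16 log units; beyond the scatter). Compound 4 gives > 100000 nM, which is a limit of the assay and not a number, so the step gives only the smallest size the change could have, and the true loss could be larger. Compounds 1 and 2 differ from compound 3 in more than one place and could not single out any one group, whereas this pair ties the loss of a measurable value to this one hydroxy group, and compound 4 now joins them at the limit: the limit of > 100000 nM in this assay, at which 3 of the 4 values shown sit.

Among the compounds shown here, it remains open whether the hydroxy group is the only group that works at this place on the ring, or whether an amine or a carboxylic acid there would also keep a measurable value. Also open, on these data alone, is how much the bromo group and the sulfur-linked substituent each contribute while the hydroxy group stays in place.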